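Imidazole for Pyridine on the Alkyne Arm

A few compounds are considered here, and "the series" means these few. Any claim that something is new, unique, unknown or untested is made for them only; others in the source may bear on it.

In an assay on CHO cells for displacement of a labelled ligand from prostaglandin D2 receptor 2 (Homo sapiens), read by scintillation counting (on this read-out lower numbers stand for stronger inhibition and higher numbers for weaker inhibition), compound 1 `O=C(O)COc1ccc(Cl)cc1C#Cc1ccc(CO)cc1F` gives 28 nM, compound 2 `COc1ccccc1C#Cc1cc(Cl)ccc1OCC(=O)O` gives 190 nM, and compound 3 `O=C(O)COc1ccc(Cl)cc1C#Cc1ccncc1` gives 601 nM. Compound 3 thus stands highest of the three in this assay, with gaps beyond the scatter to both compound 2 and compound 1. Compound 4 `Cn1ccnc1C#Cc1cc(Cl)ccc1OCC(=O)O` has not yet been measured in this assay. It differs from compound 3 in one place: 1-methyl-1H-imidazol-2-yl in place of pyridin-4-yl on a triple-bonded carbon. Going by the values given here, no measured pair in this set shows a change of this kind, so the size of the step rests on judgement alone. The expected step is a 1.2-fold higher number from compound 3 to compound 4 (0.07 log units; within the scatter), which is no more than the scatter, in no firm direction. For compound 4 the estimate in this assay is 700 nM, within a range of 250 nM to 2000 nM.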

Compound 4, inhibition constant: 1470 nM
Compound 4: middle estimate off by 2.1-fold (0.32 log units), on the low side; the range from low to high includes it.
By their numbers in this assay, from the lowest: compound 1; then compound 2; then compound 3; then compound 4.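

In this assay, 1-methyl-1H-imidazol-2-yl in place of pyridin-4-yl on the triple-bonded carbon gives a 2.4-fold higher number from compound 3 to compound 4 (0.39 log units; beyond the scatter). This position therefore responds to the ring type even when the heavy-atom count stays the same, and here the five-membered ring gives the weaker inhibition. Nothing measured here accounts for this step.

The compounds shown leave open whether the loss follows from the imidazole ring itself or from its methyl group. They also leave open how a plain 1H-imidazol-2-yl, or a pyridine ring carrying an amine, would read at this position.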